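The source may hold more compounds than are shown below. What is called first, only, known or untested is meant among the compounds shown, and "the series" means these compounds.

- Compound 1 `COc1cc(OC)c2c(=O)c(OCC(=O)N/N=C/c3sccc3C)c(-c3cc(OC)c(OC)c(OC)c3)oc2c1`: 4470 nM
- Compound 2 `COc1cc(OC)c2c(=O)c(OCCCCN3CCCC3)c(-c3cc(OC)c(OC)c(OC)c3)oc2c1`: 10400 nM

In a functional assay on MDA-MB-231 cells (Homo sapiens) for cytotoxicity, read by MTT assay, with a stated time of 38 h (on this read-out higher numbers stand for weaker inhibition and lower numbers for stronger inhibition), compound 2 gives 10400 nM as the higher of the two numbers, so it is the weaker inhibitor of this pair. Compound 3 `COc1cc(OC)c2c(=O)c(OCC(=O)N/N=C/c3ccc(C)cc3)c(-c3cc(OC)c(OC)c(OC)c3)oc2c1` is still unmeasured, and it differs from compound 2 in one place: a group of 12 heavy atoms (9 carbon, 2 nitrogen, 1 oxygen; one six-membered aromatic ring of carbon only) in place of a group of 8 heavy atoms (7 carbon, 1 nitrogen; one five-membered non-aromatic ring with 1 hetero atom), on a saturated chain carbon bound to an oxygen on an aromatic ring. Within the data shown here, only one measured step bears on this: a 2.3-fold higher number from compound 1 to compound 2 (0.37 log units; beyond the scatter) and that counts as modest. In that step the ring-bearing hydrazone-type side chain of compound 1 gave way to the pyrrolidine chain, so the change to compound 3 runs roughly the other way. However, compound 3 carries a six-membered aromatic ring of carbon only where compound 1 has a five-membered aromatic ring, and no measurement shows what that difference does. The expected shift is a 2.3-fold lower number from compound 2 to compound 3 (0.36 log units; beyond the scatter) of similar modest size, towards stronger inhibition. In this assay compound 3 is estimated at 4500 nM with 1700 nM to 11000 nM as its expected range.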

Compound 3, half-maximal inhibitory concentration: 4570 nM
Estimate against measurement, compound 3: 1.0-fold (0.01 log units) below; the measured number falls inside the stated range.
By their numbers in this assay, from the lowest: compounds 1 and 3 (each within the scatter of the next); then compound 2.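

In this assay, 4-methylphenyl in place of 3-methylthiophen-2-yl on a carbon with a double bond to nitrogen gives a 1.0-fold higher number from compound 1 to compound 3 (0.01 log units; within the scatter) and so leaves the number unchanged within the scatter, which shows that this ring swap at the end of the side chain has no readable effect here. The pyrrolidine chain now stands against two compounds with different end rings, and the second comparison, a 2.3-fold lower number from compound 2 to compound 3 (0.36 log units; beyond the scatter) in this assay, matches the first one in direction and size. No measurement available here gives a reason for either result.

As far as these compounds go, it remains open what an amine or a carboxylic acid in place of the methyl on the phenyl ring would do. A morpholine in place of the pyrrolidine, or a longer chain carrying it, is also untested among these compounds.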